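The source may hold more compounds than are shown below. What is called first, only, known or untested is meant among the compounds shown, and "the series" means these compounds.

Working notes on the step from compound 3 to compound 4. In a functional assay on NALM-6 cells (Homo sapiens) for cytotoxicity, with a stated time of 72 h (on this read-out higher numbers stand for an effect only at larger amounts of compound and lower numbers for an effect already at smaller amounts), compound 1 (`C=C[C@@](C)(/C=C/c1ccc(Nc2ccc(F)cc2)cc1)CCC=C(C)C`) gives > 43400 nM, which is a limit and not a number. Compound 2 (`C=C[C@@](C)(/C=C/c1ccc(Nc2ccc(Cl)cc2)cc1)CCC=C(C)C`) gives > 43400 nM, also a limit. Compound 3 (`C=C[C@@](C)(/C=C/c1ccc(-c2ccc(Cl)cc2)cc1)CCC=C(C)C`) gives > 43400 nM, again a limit. Compound 3 therefore has no number of its own and stands with the other two at the limit of > 43400 nM in this assay, at which 3 of the 3 values shown sit.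

Compound 4 (`C=C[C@@](C)(/C=C/c1ccc(-c2ccc(Cl)c(Cl)c2)cc1)CCC=C(C)C`) carries chloro in place of hydrogen on an aromatic carbon, ortho to a chloro group and meta to a large group, taking 4-chlorophenyl to 3,4-dichlorophenyl: chloro in place of hydrogen on an aromatic carbon.

Within the data shown here, three measured steps bear on this change only indirectly: a step that the two limits leave unreadable from compound 1 to compound 2, a step that the two limits leave unreadable from compound 1 to compound 3 and a step that the two limits leave unreadable from compound 2 to compound 3. None has a readable size, and none adds a chloro in place of hydrogen. They offer no size or direction to carry over, so no step beyond the scatter is expected in this assay, and another limit is the likeliest report. The expectation rests on compound 3, whose limit is > 43400 nM. Among the measured compounds shown here, the expected move is a step that the limit leaves unreadable from compound 3 to compound 4, an estimate with no measured step behind its size. The estimate for compound 4 is 45000 nM, with an expected range of 20000 nM to 90000 nM.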

Compound 4, half-maximal effective concentration: > 43400 nM
Compound 4 gave a limit, no number (the forecaster's own chance of this, stated with the estimate: 75%); the middle value is on the limit's open side.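

Compound 4 adds no readable step to compound 1, compound 2 or compound 3 in this assay, as each compound carries a limit and not a number: the limit of > 43400 nM in this assay, at which 4 of the 4 values shown sit.

The compounds shown leave open the size of the change from 4-chlorophenyl to 3,4-dichlorophenyl, and whether any change on the shared core gives a number in this assay.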